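Carbamate to Oxadiazole on the Ring Amine Nitrogen

The compounds below may be only part of what the source reports. "The series", "measured", "known", "first", "only" and "open" are said of these compounds alone.

compound 1 `CC(C)(C)OC(=O)N1CCC(Oc2cccc3c2CCN3c2ccc(S(C)(=O)=O)cc2)CC1` — 92%
compound 2 `CC(C)OC(=O)N1CCC(Oc2ncnc3c2CCN3c2ccc(-c3cccn3C)cc2F)CC1` — 44%
compound 3 `CC(C)(C)COC(=O)N1CCC(Oc2ncnc3c2CCN3c2ccc(S(C)(=O)=O)cc2F)CC1` — 80%

Of the compounds shown here, three have been measured in a functional assay on CHO-K1 cells with Glucose-dependent insulinotropic receptor (Homo sapiens) as the target, read by a luciferase reporter, with a stated time of 5 h; on this read-out higher numbers stand for larger maximal responses and lower numbers for smaller maximal responses. Compound 1 reaches 92%, compound 2 reaches 44%, and compound 3 reaches 80%. Compound 3 thus stands second highest of the three numbers: compound 1 lies higher by a gap beyond the scatter, and compound 2 lies lower by a gap that is also beyond the scatter. Each of these three differs from the others in more than one place, so none of the gaps can be tied to a single structural change.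

The next compound, compound 4 `CC(C)c1noc(N2CCC(Oc3ncnc4c3CCN4c3ccc(S(C)(=O)=O)cc3F)CC2)n1`, differs from compound 3 in one place only: 3-isopropyl-1,2,4-oxadiazol-5-yl in place of neopentyloxycarbonyl on an amine nitrogen in a ring. The other parts of compound 3 are kept. Within the data shown here, no measured pair shows this kind of change, so nothing among the measured numbers says how large the step in this assay should be; with the carbonyl of the carbamate gone and a five-membered aromatic ring in its place, the group that enters fills about the same space as the one that leaves. Compound 4 is therefore expected to stay close to compound 3, with a step from compound 3 to compound 4 of a number 4 percentage points lower from compound 3 to compound 4 (within the scatter), which would be within the scatter. The estimate for compound 4 is 76%, with a range from 52% to 95%.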

Compound 4, largest response reached (reported as percent of maximum), in percent of the reference or control that the assay uses: 124%
Beside the measured number, compound 4's estimate is 48 percentage points below it, and the stated range ends below it.
By their numbers in this assay, from the lowest: compound 2; then compound 3; then compound 1; then compound 4.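

In this assay, putting 3-isopropyl-1,2,4-oxadiazol-5-yl in place of neopentyloxycarbonyl on an amine nitrogen in a ring, with the rest of the structure kept, gives a number 44 percentage points higher from compound 3 to compound 4 (beyond the scatter). Among these compounds, this is the first comparison in the set that isolates one place, and it shows that the maximal response depends strongly on the group at this nitrogen, even though the group that leaves and the group that enters hold the same number of heavy atoms. Nothing measured here bears on the reason for so large a step.

The compounds shown leave open whether the step belongs to the five-membered aromatic ring itself or to the isopropyl it carries, since they include no tert-butyl or cyclopropyl on that ring and no pyrimidine on the same nitrogen. They also leave open whether the same exchange would raise the response on the core of compound 1 or with the aryl group of compound 2, as this single pair gives one step in one setting.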